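A few compounds are considered here, and "the series" means these few. Any claim that something is new, unique, unknown or untested is made for them only; others in the source may bear on it.

Measured compounds in an ADME assay on MT4 cells (Homo sapiens) for cytotoxicity, read by MTT assay, with a stated time of 5 days; a lower number here means that less compound is tolerated, a higher number that more compound is tolerated: compound 1 `N#Cc1ccc(Nc2nccc(OCc3ccccc3Br)n2)cc1` gives 130000 nM; compound 2 `N#Cc1ccc(Nc2nccc(OCc3cccc(F)c3)n2)cc1` gives 105000 nM; compound 3 `COc1ccccc1COc1ccnc(Nc2ccc(C#N)cc2)n1` gives 8900 nM.

Compound 3 stands lowest of the three in this assay, so it is the least well tolerated: the step of a 15-fold lower number from compound 1 to compound 3 (1.16 log units; beyond the scatter) and the step of a 12-fold lower number from compound 2 to compound 3 (1.07 log units; beyond the scatter) are both large and beyond the scatter, whereas a 1.2-fold lower number from compound 1 to compound 2 (0.09 log units; within the scatter) is within it. Compound 4 `N#Cc1ccc(Nc2nccc(OCc3ccccc3)n2)cc1` differs from compound 3 by hydrogen in place of methoxy on an aromatic carbon. Among the compounds with values here, the change undoes the methoxy group that separates compound 3 from the other two, and the steps that bear on it are those leading into compound 3: the arrival of methoxy in place of bromo lowered the number in a 15-fold lower number from compound 1 to compound 3 (1.16 log units; beyond the scatter), and the switch of the whole benzylic ring did so in a 12-fold lower number from compound 2 to compound 3 (1.07 log units; beyond the scatter). Both companions of compound 3 that lack methoxy, compound 1 and compound 2, sit high and close to each other. Within the data shown here, removing methoxy is therefore expected to move the number back up, with a step of roughly a 6.7-fold higher number from compound 3 to compound 4 (0.83 log units; beyond the scatter), though the bare phenyl has no direct precedent among the measured compounds, so the range is wide. Compound 4 is estimated at 60000 nM, between 15000 nM and 150000 nM.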

Compound 4, half-maximal cytotoxic concentration: 13000 nM
Estimate against measurement, compound 4: 4.6-fold (0.66 log units) above, and the stated range ends above it.
By their numbers in this assay, from the lowest: compounds 3 and 4 (each within the scatter of the next); then compounds 2 and 1 (each within the scatter of the next).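

In this assay, taking methoxy off the ring carbon gives a 1.5-fold higher number from compound 3 to compound 4 (0.16 log units; within the scatter), so the methoxy group is not what separates compound 3 from the two high-standing compounds, and the unsubstituted phenyl stays in the low group with the 2-methoxyphenyl. The larger differences appear instead when a halogen is removed: hydrogen in place of fluoro gives an 8.1-fold lower number from compound 2 to compound 4 (0.91 log units; beyond the scatter), and hydrogen in place of bromo gives a 10-fold lower number from compound 1 to compound 4 (1.00 log units; beyond the scatter). Among these four compounds, then, the higher numbers go with the two halogen-bearing rings, while hydrogen and methoxy on the ring give numbers within the scatter of each other, and no compound shown goes against this pattern.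

No supporting measurement bears on why the fluoro and bromo compounds stand apart from the other two. The compounds shown also leave open whether this pattern extends to other halogens such as chloro, and how the number would respond to an amine, a carboxylic acid or a longer chain on this ring.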